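Methyl to nitro on the shared core: working notes

This account rests on a few compounds, and the source may have more. Where it says the series, first, only, none or still open, it means among the compounds named here.

Measured so far in a functional assay on the whole organism (strain albino) with Mus musculus as the target, with a stated time of 0.5 h; on this read-out higher numbers stand for an effect only at larger amounts of compound and lower numbers for an effect already at smaller amounts:
- compound 1 `Cc1ccc2nc(NC(=O)/C=C/OC3=CC=C3)sc2c1` gives "not determined" (no result reported)
- compound 2 `COc1ccc(C2CC(Nc3nc4ccc(C)cc4s3)=NN2C(C)=O)cc1` gives 39.4 umol/kg
- compound 3 `O=C(/C=C/OC1=CC=C1)Nc1nc2ccc([N+](=O)[O-])cc2s1` gives "not determined" (no result reported)

Among the measured compounds shown here, compound 2 holds the only number in this small set, at 39.4 umol/kg. No ranking follows from it, since neither of the other two compounds has a numerical result. For the measured compounds named here, no measured step between two compounds is available either, so the size of any structural effect in this assay remains open.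

The next compound is compound 4 `COc1ccc(C2CC(Nc3nc4ccc([N+](=O)[O-])cc4s3)=NN2C(C)=O)cc1`, which departs from compound 2 at one place. It has nitro in place of methyl on an aromatic carbon. The site lies on a six-membered aromatic ring of carbon only, part of a fused or bridged system of two rings.

Going by the values given here, with no measured step to draw on, the expectation starts from compound 2 at 39.4 umol/kg and favours neither direction. The estimated change is a 1.0-fold higher number from compound 2 to compound 4 (0.01 log units; within the scatter), so no step beyond the scatter is expected. The range is kept wide because a single value anchors it. For compound 4 the expected value is 40 umol/kg, with an estimated range from 14 umol/kg to 115 umol/kg.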

Compound 4, dose for half-maximal effect: 149 umol/kg
The estimate for compound 4 lay 3.7-fold (0.57 log units) below the measured number; measured number above the stated range.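

Among the compounds shown here, this is the first measured step: in this assay, nitro in place of methyl on an aromatic carbon gives a 3.8-fold higher number from compound 2 to compound 4 (0.58 log units; beyond the scatter). The position is therefore not indifferent to this change, and with the acetylated side of the molecule held constant, compound 4 needs a larger amount of compound for its effect than compound 2 does, a modest shift that still lies beyond the scatter. The data offer no measured basis for explaining this shift.

As far as these compounds go, one pair is a single step at one site, so it gives a direction for this exchange only and no trend across substituents; compound 1 and compound 3 differ by the same change but carry no numbers, so the step between them cannot be read, and whether it would follow the same direction stays open. Also open, from the compounds shown here alone, is how an amine, a carboxylic acid or a longer alkyl chain at this place would compare with methyl and nitro. Going by these compounds, compound 2 gives 39.4 umol/kg, and whether any such group would bring the read-out to a lower number stays open as well.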